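Furan-2-yl Carbinol in Place of the Arylthioether

The source may report more compounds than this note shows. Statements on the series, on what has been measured and on what is new or still open speak of the compounds shown alone.

Compound 3 `CSc1ccc(C(O)CC2CCN(Cc3ccccc3)CC2)cc1` gives 10 nM in an assay on isolated protein for binding affinity to Sigma non-opioid intracellular receptor 1 (Mus musculus) (a lower number here means a stronger inhibitor, a higher number a weaker inhibitor), the lowest of the three numbers gathered so far. Compound 2 `CS(=O)(=O)c1ccc(C(=O)CC2CCN(Cc3ccccc3)CC2)cc1` gives 18 nM in this assay, and this sits within the scatter of compound 3, so the two cannot be ranked. Compound 1 `O=C(CC1CCN(Cc2ccccc2)CC1)c1ccc(CO)cc1` gives 31 nM in this assay, and here the gap to compound 3 lies beyond the scatter. Going by the values given here, the only step between measured compounds that differ in one place is a 1.7-fold lower number from compound 1 to compound 2 (0.24 log units; within the scatter).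

Compound 4 `OC(CC1CCN(Cc2ccccc2)CC1)c1ccco1` has not been measured. It differs from compound 3 in one place: furan-2-yl in place of 4-(methylsulfanyl)phenyl on a saturated chain carbon bound to an oxygen on a saturated carbon and a saturated chain carbon. Among the compounds with values here, no measured step touches this position. The step from compound 1 to compound 2 exchanges a substituent on the six-membered aromatic ring of a ketone and stayed within the scatter, so it offers no direct guidance on exchanging that whole ring for a five-membered one at the carbinol carbon. All three measured compounds carry the six-membered aromatic ring of carbon only, and compound 4 gives it up, so a modest weakening is expected, though it may well remain within the scatter. Compound 4 is therefore estimated at 30 nM, with a range of 8 nM to 120 nM, which means an expected step of a 3.0-fold higher number from compound 3 to compound 4 (0.48 log units; beyond the scatter).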

Compound 4, inhibition constant: 11 nM
Beside the measured number, compound 4's estimate is 2.7-fold (0.44 log units) above it; the measured number falls inside the stated range.
By their numbers in this assay, from the lowest: compounds 3, 4, 2 and 1 (each within the scatter of the next, the first and the last beyond it).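

At the saturated chain carbon bound to an oxygen, furan-2-yl in place of 4-(methylsulfanyl)phenyl gives a 1.1-fold higher number from compound 3 to compound 4 (0.04 log units; within the scatter) in this assay, so compound 3 and compound 4 cannot be ranked. Going by these compounds alone, this pair shows what the earlier compounds could not: in this one comparison, the six-membered aromatic ring of carbon only can give way to a five-membered aromatic ring with 1 hetero atom, and a group of 8 heavy atoms to one of 5, without a change that can be read beyond the scatter. Nothing at hand explains why the exchange leaves the number within the scatter.

From the compounds shown here alone, one pair cannot show how widely this tolerance extends, so what a thiophen-2-yl, a pyridin-3-yl or a saturated cyclohexyl group would give on this carbon remains open. Also open, going by these compounds, is whether furan-2-yl would behave the same way with a ketone carbonyl in place of the hydroxyl, since the ketones compound 1 and compound 2 both carry a six-membered aromatic ring of carbon only.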